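The compounds below may be only part of what the source reports. "The series", "measured", "known", "first", "only" and "open" are said of these compounds alone.

Of the compounds shown here, three on one shared core have been tested so far in a functional assay on HCT-116 cells (Homo sapiens) for inhibition, read by MTT assay, with a stated time of 48 h; on this read-out higher numbers stand for weaker inhibition and lower numbers for stronger inhibition. Compound 1 (`COc1ccc(-n2c(SC)nnc2-c2cc(OC)c(OC)c(OC)c2)cc1`) reads > 60000 nM as a limit of the assay, not a number. Compound 2 (`COc1ccc(-n2c(SCC(=O)c3ccccc3)nnc2-c2cc(OC)c(OC)c(OC)c2)cc1`) reads > 60000 nM and this too is only a limit. Within the data shown here, compound 3 (`COc1cc(-c2nnc(SCC(=O)c3ccccc3)n2-c2ccc(N(C)C)cc2)cc(OC)c1OC`) gives 42500 nM as the only true number in the set, so it cannot be placed exactly against the other two.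

Compound 4 (`COc1cc(-c2nnc(SCC(=O)Nc3ccc(Cl)cc3)n2-c2ccc(N(C)C)cc2)cc(OC)c1OC`) keeps all of compound 3 but one group, with (4-chlorophenyl)amino in place of phenyl on a carbonyl carbon. Benzoyl thus becomes (4-chlorophenyl)carbamoyl. Two measured steps offer some guidance, though neither is this change. At this same group, benzoyl in place of hydrogen gave a step that the two limits leave unreadable from compound 1 to compound 2 and so no usable size. Elsewhere on the molecule, dimethylamino in place of methoxy gave an at least 1.4-fold lower number from compound 2 to compound 3 (0.14 log units; that floor lies within the scatter) and so nothing firm either.

The data therefore set no size for the new change. Starting from compound 3 at 42500 nM, a cautious guess is a modest move in this assay toward a lower number, meaning stronger inhibition. Estimated on that basis, the expected change is a 2.1-fold lower number from compound 3 to compound 4 (0.33 log units; beyond the scatter) and the real one may be smaller or reversed. For compound 4 the estimated value is 20000 nM, with a wide expected range (4000 nM to 60000 nM).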

Compound 4, half-maximal inhibitory concentration: 39300 nM
The estimate for compound 4 lay 2.0-fold (0.29 log units) below the measured number; low and high end bracket the measured number.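

Among these compounds, at this position, the exchange of phenyl for (4-chlorophenyl)amino on a carbonyl carbon gives the first step with a readable size, and in this assay it is a 1.1-fold lower number from compound 3 to compound 4 (0.03 log units; within the scatter). The entering group brings a nitrogen, a chlorine and one hydrogen-bond donor, yet the two compounds cannot be told apart on this read-out, so this exchange produces no readable gain or loss at this position. The earlier step at this group has no readable size, which leaves this single step as the only measure of the position so far, and the wider picture remains thin: the limit of > 60000 nM in this assay, at which 2 of the 4 values shown sit.

The exchange alters the linking atoms and the ring substituent together, so the compounds shown cannot separate the contribution of the amide hydrogen from that of the chlorine. Also open, from the compounds shown here alone, is whether a plain phenylamino group, a chain ending in a carboxylic acid, or a saturated amine such as morpholine on the same carbonyl carbon would move the number beyond the usual scatter.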